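Swapping the amide aryl group on a shared naphthyl core

The source may hold more compounds than are shown below. What is called first, only, known or untested is meant among the compounds shown, and "the series" means these compounds.

Measured in an assay on isolated protein for inhibition of histone deacetylase 4 (Homo sapiens), with a stated time of 1 h; a higher number here means a weaker inhibitor, a lower number a stronger inhibitor:
- compound 1, `O=C(COc1ccc2cc(/C=C3/SC(=O)NC3=O)ccc2c1)Nc1cccc(F)n1`, gives 840 nM
- compound 2, `O=C(COc1ccc2cc(/C=C3/SC(=O)NC3=O)ccc2c1)Nc1ccccc1`, gives 2100 nM
- compound 3, `Cc1cccc2sc(NC(=O)COc3ccc4cc(/C=C5/SC(=O)NC5=O)ccc4c3)nc12`, gives 1200 nM

Compound 3 stands second highest of the three numbers; its gaps to compound 1 and to compound 2 are both within the scatter. Compound 4, `O=C(COc1ccc2cc(/C=C3/SC(=O)NC3=O)ccc2c1)Nc1c(F)cc(F)cc1Br`, differs from compound 3 by 2-bromo-4,6-difluorophenyl in place of 4-methyl-1,3-benzothiazol-2-yl on an amide-type nitrogen. Going by the values given here, the steps that bear on this are all exchanges of the group on the amide nitrogen: a 2.5-fold higher number from compound 1 to compound 2 (0.40 log units; beyond the scatter), a 1.4-fold higher number from compound 1 to compound 3 (0.15 log units; within the scatter) and a 1.8-fold lower number from compound 2 to compound 3 (0.24 log units; within the scatter). Only the move to a plain phenyl went beyond the scatter, and compound 4 again carries a phenyl-based group. A small rise toward the number of compound 2 is therefore expected, likely within the scatter, as a 1.3-fold higher number from compound 3 to compound 4 (0.12 log units; within the scatter). For compound 4 the estimate is 1600 nM, in the range 600 nM to 4000 nM.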

Compound 4, half-maximal inhibitory concentration: 1100 nM
Compound 4: middle estimate off by 1.5-fold (0.16 log units), on the high side; the range from low to high includes it.
By their numbers in this assay, from the lowest: compounds 1, 4, 3 and 2 (each within the scatter of the next, the first and the last beyond it).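

In this assay, the amide-type nitrogen accepts 2-bromo-4,6-difluorophenyl in place of 4-methyl-1,3-benzothiazol-2-yl with a 1.1-fold lower number from compound 3 to compound 4 (0.04 log units; within the scatter), so a group with no hydrogen-bond acceptors reads level with one that has two. The other exchanges give a 1.9-fold lower number from compound 2 to compound 4 (0.28 log units; within the scatter) and a 1.3-fold higher number from compound 1 to compound 4 (0.12 log units; within the scatter), so compound 4 cannot be separated from any of the other three, even though compound 1 and compound 2 differ beyond the scatter. No measurement shown here explains this.

On these data alone, whether the bromine or the fluorines matter stays open, and a phenyl carrying bromine alone or fluorine alone would help separate them. As far as these compounds go, how an amine or a carboxylic acid on that phenyl would read also remains open.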